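Moving one methoxy group: compound 2 to compound 3

The compounds below may be only part of what the source reports. "The series", "measured", "known", "first", "only" and "open" are said of these compounds alone.

- compound 1 (`Cc1cccc(/C=C/c2nnc(-c3ccc4c(c3)OCCO4)o2)c1`): (201000 nM)
- compound 2 (`COc1cccc(/C=C/c2nnc(-c3ccc4c(c3)OCCO4)o2)c1`): (332000 nM)

In an ADME assay on HUVEC cells (Homo sapiens) for cytotoxicity, read by MTT assay, with a stated time of 24 h (a higher number here means that more compound is tolerated, a lower number that less compound is tolerated), compound 2 gives (332000 nM) and stands level with compound 1, the two lying within the usual scatter. Compound 3 (`COc1ccc(/C=C/c2nnc(-c3ccc4c(c3)OCCO4)o2)cc1`) carries 4-methoxyphenyl in place of 3-methoxyphenyl (4-methoxyphenyl in place of 3-methoxyphenyl on a double-bonded chain carbon bound to a double-bonded chain carbon) and is otherwise the same. Among the compounds with values here, the only measured step (a 1.7-fold higher number from compound 1 to compound 2 (0.22 log units; within the scatter)) is a different change, methoxy in place of methyl, and it stayed within the scatter. Within the data shown here, no measured step moves a group this way, so no shift beyond the scatter is expected, and no direction can be argued (estimated step a 1.2-fold lower number from compound 2 to compound 3 (0.07 log units; within the scatter)). Compound 3 is expected at (280000 nM), with an estimated range from (120000 nM) to (600000 nM).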

Compound 3, half-maximal cytotoxic concentration: 312000 nM
Compound 3: middle estimate off by 1.1-fold (0.05 log units), on the low side; the range from low to high includes it.
By their numbers in this assay, from the lowest: compounds 1, 3 and 2 (each within the scatter of the next).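

Moving the methoxy group, with 4-methoxyphenyl in place of 3-methoxyphenyl, changes little in this assay (a 1.1-fold lower number from compound 2 to compound 3 (0.03 log units; within the scatter)), so compound 2 and compound 3 stand level. Exchanging 3-methylphenyl for 4-methoxyphenyl at the same place also stays inside the usual scatter (a 1.6-fold higher number from compound 1 to compound 3 (0.19 log units; within the scatter)), so all three compounds read alike here. Nothing available explains this result.

Going by these compounds, whether an amine or a carboxylic acid on this phenyl ring would shift the number beyond the scatter remains open.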